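Ethoxy for methoxy on the aryl ring of compound 1

The source may hold more compounds than are shown below. What is called first, only, known or untested is meant among the compounds shown, and "the series" means these compounds.

For the measured compounds named here, compound 1 `COC(=O)N1N=C(c2cccc(OC)c2)CC1c1cc(OC)c(OC)c(OC)c1` is the only compound of this pair with a numerical value in a functional assay on HeLa cells (Homo sapiens) for antiproliferative activity, read by MTT assay, with a stated time of 48 h; a higher number here means a weaker inhibitor of growth, a lower number a stronger inhibitor of growth: there compound 1 gives 1530 nM. Compound 2 `COc1cccc(C2=NN(C(=O)OCc3ccccc3)C(c3cc(OC)c(OC)c(OC)c3)C2)c1` reaches only a limit of the assay, > 10000 nM, so (the limit of > 10000 nM in this assay, at which 1 of the 2 values shown sits). Going by the values given here, the one measured step, an at least 6.5-fold higher number from compound 1 to compound 2 (0.81 log units; beyond the scatter), concerns phenyl in place of hydrogen on a saturated chain carbon bound to an oxygen next to a carbonyl group, and it worsened growth inhibition markedly. Among the compounds with values here, compound 3 `CCOc1cccc(C2=NN(C(=O)OC)C(c3cc(OC)c(OC)c(OC)c3)C2)c1` differs from compound 1 elsewhere, by methyl in place of hydrogen on a saturated chain carbon bound to an oxygen on an aromatic ring, so no measured step touches the same place, and the data give no reading of methoxy to ethoxy on the shared core. Compound 3 is therefore expected to sit close to compound 1, with a step of a 1.3-fold higher number from compound 1 to compound 3 (0.12 log units; within the scatter), within the usual scatter. The estimate for compound 3 in this assay is 2000 nM, between 700 nM and 6000 nM.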

Compound 3, concentration for 50% growth inhibition: 4970 nM
The estimate for compound 3 lay 2.5-fold (0.40 log units) below the measured number; measured number inside the range.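

Methoxy to ethoxy on the 3-methoxyphenyl group, a single methyl in place of hydrogen on a saturated chain carbon bound to an oxygen on an aromatic ring, gives a 3.2-fold higher number from compound 1 to compound 3 (0.51 log units; beyond the scatter) in this assay. For the compounds shown here, this is the first reading of this place, and it shows that even this small enlargement weakens growth inhibition, so the place changed in compound 2 is not the only one that responds to added carbon. Nothing measured here gives a cause for this step.

The compounds shown leave open whether the loss continues with a longer chain such as propoxy. They also leave open whether a hydroxyl group or a fluorine atom in place of the methoxy would give a lower number than compound 1.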